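Phenyl in Place of Cyclobutylmethyl at the Ring Nitrogen

The source may report more compounds than this note shows. Statements on the series, on what has been measured and on what is new or still open speak of the compounds shown alone.

In an ADME assay on the whole organism (plasma) for pharmacokinetics, with Rattus norvegicus as the target, with a stated time of 6 h, at a dose of 10 mg/kg by the oral route (on this read-out lower numbers stand for lower exposure and higher numbers for higher exposure at the dose given), compound 3 `Cc1nc(NCC2CCC2)nc(N[C@@H]2C[C@H](CO)[C@@H](O)[C@H]2O)c1-c1nc2ccccc2s1` gives 228 ng.h/mL. It stands between the other two measured compounds: compound 1 `Nc1ncc(-c2nc3ccccc3s2)c(N[C@@H]2C[C@H](CO)[C@@H](O)[C@H]2O)n1` gives 149 ng.h/mL, and compound 2 `Cc1nc(NC(C)C)nc(N[C@@H]2C[C@H](CO)[C@@H](O)[C@H]2O)c1-c1nc2ccccc2s1` gives 8420 ng.h/mL. Among the measured compounds shown here, the only single-change step measured is a 37-fold lower number from compound 2 to compound 3 (1.57 log units; beyond the scatter). Compound 4 `Cc1nc(Nc2ccccc2)nc(N[C@@H]2C[C@H](CO)[C@@H](O)[C@H]2O)c1-c1nc2ccccc2s1` differs from compound 3 by phenyl in place of cyclobutylmethyl on a nitrogen on an aromatic ring. For the measured compounds named here, no measured step exchanges an alkyl for phenyl on this nitrogen, so the one step at this position is only a loose guide: it shows that a change there can move exposure greatly, but it gives no direction for phenyl. The step is therefore expected to be modest, a 1.3-fold higher number from compound 3 to compound 4 (0.12 log units; within the scatter), with a wide range. Compound 4 is estimated at 300 ng.h/mL, between 60 ng.h/mL and 1500 ng.h/mL.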

Compound 4, area under the concentration-time curve: 742 ng.h/mL
Compound 4: the middle estimate sits 2.5-fold (0.39 log units) below what was measured; low and high end bracket the measured number.
By their numbers in this assay, from the lowest: compounds 1 and 3 (each within the scatter of the next); then compound 4; then compound 2.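

At the nitrogen on an aromatic ring, an aromatic group now has a measured place in this assay: phenyl in place of cyclobutylmethyl gives a 3.3-fold higher number from compound 3 to compound 4 (0.51 log units; beyond the scatter), while phenyl in place of isopropyl gives an 11-fold lower number from compound 2 to compound 4 (1.05 log units; beyond the scatter). Among these three groups, phenyl therefore sits in the middle, and the isopropyl of compound 2 remains clearly ahead of both ring-bearing groups. No evidence is available to explain this order.

On these data alone, whether a methoxyphenyl or pyridyl group would behave like phenyl here remains open. So does whether an ethyl or tert-butyl chain would come closer to compound 2.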